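A few compounds are considered here, and "the series" means these few. Any claim that something is new, unique, unknown or untested is made for them only; others in the source may bear on it.

Measured so far:
Compound 1 `Cn1ccc2ccc(-c3cc(Nc4ccccc4S(N)(=O)=O)cc4nccnc34)cc21` gives 37600 nM in an assay on lysate for inhibition of 6-phosphofructo-2-kinase/fructose-2,6-bisphosphatase 3 (Homo sapiens), with stated times of 0.5 min and 45 min; on this read-out higher numbers stand for weaker inhibition and lower numbers for stronger inhibition.
Compound 2 `CNC(=O)c1ccncc1Nc1cc(-c2ccc3ccn(C)c3c2)c2nccnc2c1` gives 7020 nM in this assay.

Among the measured compounds shown here, compound 2 holds the lowest of the two numbers in this assay; its nearest neighbour is compound 1, and the only step measured so far, a 5.4-fold lower number from compound 1 to compound 2 (0.73 log units; beyond the scatter), separates them.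

Compound 3 `CN(C)C(=O)c1ccncc1Nc1cc(-c2ccc3ccn(C)c3c2)c2nccnc2c1` is the next member and has not been measured. It differs from compound 2 by methyl in place of hydrogen on an amide-type nitrogen. For the measured compounds named here, the single measured step, a 5.4-fold lower number from compound 1 to compound 2 (0.73 log units; beyond the scatter), exchanges the whole aryl group on the amine nitrogen and says nothing about methylation of the amide-type nitrogen on the methylcarbamoyl group; no measured pair bears on this change. Going by the values given here, with no step to lean on, the expectation for compound 3 in this assay is a number close to that of compound 2, with a step of a 1.1-fold higher number from compound 2 to compound 3 (0.06 log units; within the scatter) that is not expected to go beyond the scatter in either direction. The estimate for compound 3 is therefore 8000 nM, with a range from 2500 nM to 25000 nM.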

Compound 3, half-maximal inhibitory concentration: > 100000 nM
Compound 3: no number, only a limit; the forecaster's own chance of this, stated with the estimate: 5%; middle value at least 12-fold (1.09 log units) away from the limit.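

Compound 3 stands at a limit of the assay and not at a number: the limit of > 100000 nM in this assay, at which 1 of the 3 values shown sits. In this assay, methyl in place of hydrogen on the amide-type nitrogen, one added heavy atom with no ring and no net charge, gives an at least 14-fold higher number from compound 2 to compound 3 (1.15 log units; beyond the scatter), a larger change than the exchange of the whole aryl group on the amine nitrogen, a 5.4-fold lower number from compound 1 to compound 2 (0.73 log units; beyond the scatter). Among the compounds shown here, the earlier step showed only that the group on the amine nitrogen could be exchanged with a measurable result, whereas this pair shows that the read-out also responds strongly to a small change within the methylcarbamoyl group, going from methylcarbamoyl to dimethylcarbamoyl.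

From the compounds shown here alone, these compounds cannot separate the loss of the amide hydrogen from the added methyl carbon as the source of the step, and how far compound 3 lies past its limit remains unknown. A primary carboxamide, an ethylcarbamoyl group or a carboxylic acid in place of the methylcarbamoyl group would bear on this, while a single pair on the shared core sets no general pattern for the series.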